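The source may hold more compounds than are shown below. What is called first, only, known or untested is meant among the compounds shown, and "the series" means these compounds.

In a functional assay on HepG2 cells (Homo sapiens) for antiproliferative activity, read by MTT assay, with a stated time of 48 h (on this read-out lower numbers stand for stronger inhibition and higher numbers for weaker inhibition), compound 1 (`Clc1ccccc1CSc1nnc(-c2cnccn2)o1`) gives 12300 nM and compound 2 (`Brc1ccc(CSc2nnc(-c3cnccn3)o2)cc1`) gives 13200 nM on the same test. Compound 3 (`Clc1cccc(CSc2nnc(-c3cnccn3)n2-c2ccccc2)c1`) gives 19600 nM there, within the usual scatter of both, so it cannot be set apart from them. Compound 4 (`Fc1cccc(F)c1CSc1nnc(-c2cnccn2)n1-c1ccccc1`) differs from compound 3 in one group: 2,6-difluorophenyl in place of 3-chlorophenyl on a saturated chain carbon bound to a sulfur. Going by the values given here, no measured pair shows what such a swap does, so no step beyond the scatter is expected, in either direction. The expected change is a 1.2-fold lower number from compound 3 to compound 4 (0.06 log units; within the scatter) and stays within the scatter. This expectation takes compound 3 at 19600 nM as its starting point. In this assay compound 4 is estimated at 17000 nM (range 7000 nM to 40000 nM).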

Compound 4, half-maximal inhibitory concentration: 22600 nM
Compound 4: the middle estimate sits 1.3-fold (0.12 log units) below what was measured; measured number inside the range.
By their numbers in this assay, from the lowest: compounds 1, 2, 3 and 4 (each within the scatter of the next).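

In this assay, 2,6-difluorophenyl in place of 3-chlorophenyl on a saturated chain carbon bound to a sulfur gives a 1.2-fold higher number from compound 3 to compound 4 (0.06 log units; within the scatter). This swap changes both the halogen and the number of halogens on the ring, yet the two compounds cannot be told apart, a finding that holds for this single pair only. Nothing measured here explains why they read alike.

On these data alone, whether an amine or a carboxylic acid on that ring, or a longer chain in place of the benzyl group, would shift the number beyond the scatter stays open.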